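This account rests on a few compounds, and the source may have more. Where it says the series, first, only, none or still open, it means among the compounds named here.

Compound 2 `COc1ccc([C@H]2CC(=O)N(c3cccc(C)c3)C2)cc1OC1CCCC1` is the starting point. In a functional assay on HEK293 cells (Homo sapiens) for cytotoxicity (a higher number here means that more compound is tolerated, a lower number that less compound is tolerated), compound 2 gives only the limit > 10000 nM, not a number. Compound 1 `COc1ccc([C@H]2CC(=O)N(c3ccccc3C)C2)cc1OC1CCCC1` likewise sits at the limit > 10000 nM. Going by the values given here, compound 3 `COc1ccc([C@H]2CC(=O)N(c3ccc([S+](C)[O-])cc3)C2)cc1OC1CCCC1` gives 7510 nM, so that an at least 1.3-fold lower number from compound 2 to compound 3 (0.12 log units; that floor lies within the scatter) and an at least 1.3-fold lower number from compound 1 to compound 3 (0.12 log units; that floor lies within the scatter) are the only readable steps, while a step that the two limits leave unreadable from compound 1 to compound 2. Compound 4 `COc1ccc([C@H]2CC(=O)N(c3cccc(NS(=O)(=O)c4cccc(Cl)c4)c3)C2)cc1OC1CCCC1` carries ((3-chlorophenyl)sulfonyl)amino in place of methyl on an aromatic carbon. Among the compounds with values here, the one step that bears on this, from compound 2 to compound 3, is small at its floor and unreadable above it, because the limit of > 10000 nM in this assay, at which 2 of the 3 values shown sit, hides where compound 2 truly lies. Compound 4 is therefore expected to show at most a modest drop, an at least 1.4-fold lower number from compound 2 to compound 4 (0.15 log units; that floor lies within the scatter), with a fair chance of another limit. The estimate for compound 4 is 7000 nM, between 2000 nM and 15000 nM.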

Compound 4, half-maximal cytotoxic concentration: > 10000 nM
Compound 4 ended at the assay's limit; the forecaster's own chance of this, stated with the estimate: 40%; at least 1.4-fold (0.15 log units) between middle value and limit.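

In this assay compound 4 ends at a limit, as compound 2 does, so no step can be read between compound 2 and compound 4. The compounds shown leave open whether ((3-chlorophenyl)sulfonyl)amino in place of methyl changes the number at all: the limit of > 10000 nM in this assay, at which 3 of the 4 values shown sit.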